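Compound 3 to compound 4: a new aryl amide

The compounds below may be only part of what the source reports. "The series", "measured", "known", "first", "only" and "open" are said of these compounds alone.

In a functional assay on A549 cells (Homo sapiens) for inhibition, read by CCK-8 assay, with a stated time of 72 h, tested at 10 uM (on this read-out higher numbers stand for more inhibition of growth at the one concentration tested and lower numbers for less inhibition of growth), compound 3 `CN(C)C(=O)c1cc2cnc(Nc3ccc(NC(=O)C4(C(=O)Nc5cccc(Br)c5)CC4)cc3)nc2n1C1CCCC1` gives 92.2%. Compound 2 `CN(C)C(=O)c1cc2cnc(Nc3ccc(NC(=O)C4(C(=O)Nc5ccc(Cl)c(C(F)(F)F)c5)CC4)cc3)nc2n1C1CCCC1` gives 88.1%, and compound 1 `COc1ccc(NC(=O)C2(C(=O)Nc3ccc(Nc4ncc5cc(C(=O)N(C)C)n(C6CCCC6)c5n4)cc3)CC2)cc1` gives 78.5%. Compound 4 `CN(C)C(=O)c1cc2cnc(Nc3ccc(NC(=O)C4(C(=O)Nc5ccc(C(F)(F)F)cc5)CC4)cc3)nc2n1C1CCCC1` carries 4-(trifluoromethyl)phenyl in place of 3-bromophenyl on an amide-type nitrogen.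

Among the measured compounds shown here, no measured step makes this exact change. The nearest evidence is the trifluoromethyl-bearing group of compound 2, which shows a number 4.1 percentage points higher from compound 2 to compound 3 (within the scatter). The 4-methoxyphenyl group of compound 1 alone falls clearly apart, with a number 13.7 percentage points higher from compound 1 to compound 3 (beyond the scatter), while the other step from it is a number 9.6 percentage points higher from compound 1 to compound 2 (within the scatter). No step beyond the scatter is therefore expected in this assay, only a slight drift downward at most. The expected step is a number 4.2 percentage points lower from compound 3 to compound 4 (within the scatter). The estimate for compound 4 is 88%, with an expected range of 78% to 96%.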

Compound 4, percent growth inhibition at one concentration: 87.9%
Estimate against measurement, compound 4: 0.1 percentage points above, within the range that was stated.
By their numbers in this assay, from the lowest: compounds 1, 4, 2 and 3 (each within the scatter of the next, the first and the last beyond it).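

In this assay the 4-(trifluoromethyl)phenyl group on the amide-type nitrogen cannot be told apart from 3-bromophenyl, with a number 4.3 percentage points lower from compound 3 to compound 4 (within the scatter), or from 4-chloro-3-(trifluoromethyl)phenyl, with a number 0.2 percentage points lower from compound 2 to compound 4 (within the scatter). Trifluoromethyl in place of methoxy on an aromatic carbon gives a number 9.4 percentage points higher from compound 1 to compound 4 (within the scatter), so among the three replacements of 4-methoxyphenyl only 3-bromophenyl stands clearly apart, with a number 13.7 percentage points higher from compound 1 to compound 3 (beyond the scatter). Nothing available accounts for these numbers.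

All groups shown at this position are substituted phenyl rings. As far as these compounds go, how a carboxylic acid or an amine on that ring, or a cyclohexyl ring in its place, would read remains open.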